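Swapping the Halophenyl Group on a Ring Nitrogen

This account rests on a few compounds, and the source may have more. Where it says the series, first, only, none or still open, it means among the compounds named here.

Three compounds sharing one core were tested in a functional assay on MCF7 cells (Homo sapiens) for inhibition, read by MTT assay, with a stated time of 72 h; on this read-out lower numbers stand for stronger inhibition and higher numbers for weaker inhibition. Compound 1 `CC(C)n1ncc2c(C(=O)Nc3cccnc3)cccc21` is the simplest of them. In this assay compound 1 gives only a limit of the assay, > 40000 nM. Compound 2 `Cc1ccc(-n2cc(CNC(=O)c3cccc4c3cnn4C(C)C)nn2)cc1C` carries a 3,4-dimethylphenyl group on an aromatic nitrogen of a five-membered aromatic ring with three nitrogens. In this assay compound 2 likewise gives only a limit, > 40000 nM. Compound 3 `CC(C)n1ncc2c(C(=O)NCc3cn(-c4ccc(I)cc4)nn3)cccc21` carries a 4-iodophenyl group on that aromatic nitrogen. In this assay compound 3 again gives only a limit, > 40000 nM. The step that the two limits leave unreadable from compound 2 to compound 3 thus cannot be read. Where compound 3 stands is known only as a limit, as for every value shown: the limit of > 40000 nM in this assay, at which 3 of the 3 values shown sit.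

Compound 4 `CC(C)n1ncc2c(C(=O)NCc3cn(-c4ccccc4F)nn3)cccc21` differs from compound 3 by 2-fluorophenyl in place of 4-iodophenyl on an aromatic nitrogen. Among the measured compounds shown here, the one measured exchange at this aromatic nitrogen, from compound 2 to compound 3, stayed unreadable, so no step beyond the scatter is expected in this assay, and another limit is the likely outcome. Compound 4 is therefore estimated at 60000 nM, with a range from 20000 nM to 200000 nM. The expected step that the limit leaves unreadable from compound 3 to compound 4 is essentially none.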

Compound 4, half-maximal inhibitory concentration: > 40000 nM
Compound 4: only a limit was reported; the forecaster's own chance of this, stated with the estimate: 80%; the middle value lies beyond the limit too.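

The steps from compound 2 to compound 4 and from compound 3 to compound 4 cannot be read, as compound 4 also gives only a limit in this assay: the limit of > 40000 nM in this assay, at which 4 of the 4 values shown sit.

The compounds shown leave open whether any group on this aromatic nitrogen gives a measurable value in this assay.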